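The source may hold more compounds than are shown below. What is called first, only, known or untested is meant among the compounds shown, and "the series" means these compounds.

Two chain amines open the series, compound 1 (`CCNCCCCNCCCNCC`) and compound 2 (`CCNCCCCNCCCCNCC`). In a functional assay on L1210 cells (Mus musculus) for inhibition, with a stated time of 96 h (on this read-out lower numbers stand for stronger inhibition and higher numbers for weaker inhibition), compound 1 gives 700 nM and compound 2 gives 350 nM. These two numbers lie within the usual scatter of each other, so compound 2 cannot be ranked ahead of compound 1.

Compound 3 (`CCNCCCCCNCCCCNCC`) carries (ethylamino)methyl in place of ethylamino on a saturated chain carbon, four bonds along the chain from an amine nitrogen. Among the measured compounds shown here, only one measured step bears on this change, the same swap three bonds along the chain, and it is a 2.0-fold lower number from compound 1 to compound 2 (0.30 log units; within the scatter). With that single small step as the guide, no step beyond the scatter is expected in this assay, and no firm direction can be given. The expected step is a 1.2-fold lower number from compound 2 to compound 3 (0.07 log units; within the scatter). For compound 3 the estimated value is 300 nM, with an expected range from 100 nM to 900 nM.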

Compound 3, half-maximal inhibitory concentration: 200 nM
Compound 3: middle estimate off by 1.5-fold (0.18 log units), on the high side; the measured number falls inside the stated range.
By their numbers in this assay, from the lowest: compounds 3, 2 and 1 (each within the scatter of the next, the first and the last beyond it).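

In this assay, the swap at this place, four bonds along the chain from an amine nitrogen, gives a 1.8-fold lower number from compound 2 to compound 3 (0.24 log units; within the scatter), so on its own it cannot be told apart from no change. Among the compounds shown here, compound 1 and compound 3 are the first pair to differ by more than the scatter: replacing ethylamino with 2-(ethylamino)ethyl gives a 3.5-fold lower number from compound 1 to compound 3 (0.54 log units; beyond the scatter), a modest step. No measurement shown here accounts for this step.

Going by these compounds, whether a 3-(ethylamino)propyl group at this place would go further in the same direction remains open. So does the effect of a different end group, such as propylamino or a carboxylic acid, in place of the ethylamino end.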